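A few compounds are considered here, and "the series" means these few. Any claim that something is new, unique, unknown or untested is made for them only; others in the source may bear on it.

Within the data shown here, compound 3 `Cc1ccc(S(=O)(=O)Nc2ccc(-c3nc4ccccc4o3)cc2)cc1` stands as the one compound with a number in an ADME assay on HEK293 cells (Homo sapiens) for cytotoxicity, read by resazurin assay, with a stated time of 48 h (a higher number here means that more compound is tolerated, a lower number that less compound is tolerated), where compound 3 gives 88000 nM. Compound 1 `COc1ccccc1S(=O)(=O)Nc1ccc(-c2nc3ccccc3o2)cc1` gives > 100000 nM, which is a limit of the assay. Compound 2 `CS(=O)(=O)Nc1ccc(-c2nc3ccccc3o2)cc1` gives > 100000 nM, again a limit and not a number. The steps to compound 3 are therefore only floors: an at least 1.1-fold lower number from compound 1 to compound 3 (0.05 log units; that floor lies within the scatter) and an at least 1.1-fold lower number from compound 2 to compound 3 (0.05 log units; that floor lies within the scatter), while a step that the two limits leave unreadable from compound 1 to compound 2. The unmeasured compound 4 `O=S(=O)(Nc1ccc(-c2nc3ccccc3o2)cc1)c1ccc(Cl)c(Cl)c1` differs from compound 3 by 3,4-dichlorophenyl in place of 4-methylphenyl on a sulfonyl sulfur. The two earlier aryl exchanges on the sulfonyl sulfur moved this assay by no readable amount beyond the floor, so no step beyond the scatter is expected here; the expected step is a 1.3-fold lower number from compound 3 to compound 4 (0.10 log units; within the scatter). Compound 4 is estimated at 70000 nM, between 25000 nM and 200000 nM.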

Compound 4, half-maximal cytotoxic concentration: > 100000 nM
Compound 4 gave a limit, no number; the forecaster's own chance of this, stated with the estimate: 40%; middle value at least 1.4-fold (0.15 log units) away from the limit.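

In this assay compound 4 gives a limit and not a number. The 3,4-dichlorophenyl group in place of 4-methylphenyl on a sulfonyl sulfur gives an at least 1.1-fold higher number from compound 3 to compound 4 (0.05 log units; that floor lies within the scatter), so two chlorine atoms on this ring brought no readable fall in the number, and the steps from compound 1 and compound 2 to compound 4 cannot be read. Any differences among these compounds stay hidden because of a single ceiling: the limit of > 100000 nM in this assay, at which 3 of the 4 values shown sit.

Going by these compounds, whether any group on this sulfur lowers the number beyond the scatter remains open. On these data alone, how an aminophenyl group, a carboxyphenyl group or a longer chain there would read in this assay also remains open.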